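Furan-2-yl Gives Way to 4-Aminophenyl

A few compounds are considered here, and "the series" means these few. Any claim that something is new, unique, unknown or untested is made for them only; others in the source may bear on it.

In a functional assay on HL-60 cells (Homo sapiens) for cytotoxicity, read by CellTiter-Blue, with a stated time of 48 h (a lower number here means a stronger inhibitor, a higher number a weaker inhibitor), compound 1 `CCOC(=O)CC1C(C(=O)OCC)=C(N)Oc2ccc(-c3ccccc3F)cc21` gives 73000 nM, and compound 2 `CCOC(=O)CC1C(C(=O)OCC)=C(N)Oc2ccc(-c3ccc(F)cc3F)cc21` gives 76600 nM, which is a 1.0-fold higher number from compound 1 to compound 2 (0.02 log units; within the scatter). Compound 3 `CCOC(=O)CC1C(C(=O)OCC)=C(N)Oc2ccc(-c3ccco3)cc21` returns only a limit, > 80000 nM, and not a number. Compound 4 `CCOC(=O)CC1C(C(=O)OCC)=C(N)Oc2ccc(-c3ccc(N)cc3)cc21` carries 4-aminophenyl in place of furan-2-yl on an aromatic carbon. Going by the values given here, the steps that bear on this change are an at least 1.0-fold higher number from compound 1 to compound 3 (0.03 log units; that floor lies within the scatter) and an at least 1.0-fold higher number from compound 2 to compound 3 (0.01 log units; that floor lies within the scatter). Neither shows a gap beyond the scatter between furan-2-yl and a fluorinated phenyl group, so only a small move towards a lower number in this assay is expected. The expected change is an at least 1.3-fold lower number from compound 3 to compound 4 (0.12 log units; that floor lies within the scatter). For compound 4, the estimated value is 60000 nM, within an expected range of 25000 nM to 100000 nM.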

Compound 4, half-maximal inhibitory concentration: 22300 nM
For compound 4 the middle estimate is 2.7-fold (0.43 log units) above the measured one; the measured number lies below the stated range.
By their numbers in this assay, from the lowest: compound 4; then compounds 1 and 2 (each within the scatter of the next). At a limit, above all of these: compound 3.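

The position now shows a step beyond the scatter: in this assay 4-aminophenyl gives a 3.4-fold lower number from compound 2 to compound 4 (0.54 log units; beyond the scatter) and a 3.3-fold lower number from compound 1 to compound 4 (0.52 log units; beyond the scatter) against the fluorinated phenyl groups. Against furan-2-yl it gives an at least 3.5-fold lower number from compound 3 to compound 4 (0.55 log units; beyond the scatter) as a floor and not as a measured size. Compound 3 holds a limit of the assay and not a number: the limit of > 80000 nM in this assay, at which 1 of the 4 values shown sits.

The compounds shown leave open whether the amine or the phenyl ring carries this step. They also leave open whether a hydroxyl, an acetamide or a carboxylic acid in the amine's place would do the same.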